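From a Limit to an Estimate: Compound 2 to Compound 4

The source may hold more compounds than are shown below. What is called first, only, known or untested is meant among the compounds shown, and "the series" means these compounds.

Measured compounds in an ADME assay on MRC5 cells (Homo sapiens) for inhibition, with a stated time of 72 h; a lower number here means that less compound is needed, a higher number that more compound is needed for the effect:
Compound 1, `CO[C@H]1CC[C@H](NC(=O)c2n[nH]cc2NC(=O)c2cnc3ccccn23)CC1`: 5900 nM
Compound 2, `COc1cccc(OC)c1C(=O)Nc1c[nH]nc1C(=O)NCc1ccccn1`: a limit only, > 50000 nM
Compound 3, `CO[C@H]1CC[C@H](NC(=O)c2n[nH]cc2NC(=O)c2ccccc2F)CC1`: 1000 nM

Compound 2 stands apart from the other two: in this assay compound 2 returns only the limit of the assay, > 50000 nM, not a number, so it sits at the limit of > 50000 nM in this assay, at which 1 of the 3 values shown sits. Within the data shown here, compounds 1 and 3 both give numbers, and the one measured step, a 5.9-fold lower number from compound 1 to compound 3 (0.77 log units; beyond the scatter), changes the group on the carbonyl carbon on the other side of the shared core, not the side changed here.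

The new compound is compound 4, `COc1cccc(OC)c1C(=O)Nc1c[nH]nc1C(=O)Nc1ccncc1`. Its difference from compound 2 is pyridin-4-yl in place of (pyridin-2-yl)methyl on an amide-type nitrogen, so the nitrogen-containing ring moves closer to the amide-type nitrogen and loses its one-carbon link. Among the measured compounds shown here, no measured step touches this position, so the measured data give no size or direction to expect beyond the scatter, and the starting point is itself a limit.

Given that compound 2 shows only a limit, compound 4 is expected to remain weak, with an estimated 50000 nM in this assay, between 10000 nM and 250000 nM, which means an estimated step of a number no higher from compound 2 to compound 4 (the limit leaves the size open).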

Compound 4, half-maximal effective concentration: > 50000 nM
Compound 4: a limit, no number; the forecaster's own chance of this, stated with the estimate: 60%; the middle value lies on the limit itself.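

In this assay compound 4, like compound 2, gives only a limit and not a number, so no step can be read between compound 2 and compound 4: the limit of > 50000 nM in this assay, at which 2 of the 4 values shown sit.

The compounds shown leave open what number either compound would give, and whether pyridin-4-yl in place of (pyridin-2-yl)methyl on the amide-type nitrogen changes that number at all.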